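The source may hold more compounds than are shown below. What is called first, only, known or untested is meant among the compounds shown, and "the series" means these compounds.

Of the compounds shown here, two with a shared core have been measured in an ADME assay on Vero cells (Chlorocebus sabaeus) for cytotoxicity, read by luminescence, with a stated time of 72 h; a lower number here means that less compound is tolerated, a higher number that more compound is tolerated. There, compound 1 `CCN1C(=O)/C(=C/c2ccc(F)cc2)S/C1=N/NC(=O)c1ccncc1` gives 9.69 ug/mL and compound 2 `CCN1C(=O)/C(=C/c2ccccc2F)S/C1=N/NC(=O)c1ccncc1` gives 22.8 ug/mL, which makes compound 2 the higher of the two numbers. Among the compounds with values here, the only measured step is a 2.4-fold higher number from compound 1 to compound 2 (0.37 log units; beyond the scatter), a modest change with 2-fluorophenyl in place of 4-fluorophenyl.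

Compound 3 `CN1C(=O)/C(=C/c2ccccc2F)S/C1=N/NC(=O)c1ccncc1` keeps the 2-fluorophenyl group and changes elsewhere: hydrogen in place of methyl on a saturated chain carbon bound to an amide-type nitrogen in a ring. In words, hydrogen stands in place of methyl on a saturated chain carbon bound to an amide-type nitrogen in a ring, which, cut one bond further out, reads ethyl to methyl.

Within the data shown here, the measured step lies at a different place, so it bears on this change only as a rough scale of size, and no measured pair varies this chain. No direction can be read from the data, and no step beyond the scatter is expected in this assay. The expected step is a 1.1-fold lower number from compound 2 to compound 3 (0.04 log units; within the scatter). For compound 3 the estimated value is 21 ug/mL, with an expected range from 9 ug/mL to 48 ug/mL.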

Compound 3, half-maximal cytotoxic concentration: 15.5 ug/mL
Estimate against measurement, compound 3: 1.4-fold (0.13 log units) above; low and high end bracket the measured number.
By their numbers in this assay, from the lowest: compounds 1, 3 and 2 (each within the scatter of the next, the first and the last beyond it).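

Hydrogen in place of methyl on a saturated chain carbon bound to an amide-type nitrogen in a ring, which reads ethyl to methyl, gives a 1.5-fold lower number from compound 2 to compound 3 (0.17 log units; within the scatter) in this assay with the 2-fluorophenyl group held fixed. Within the data shown here, the earlier pair varied only the fluorophenyl group, so this is the first measured look at this chain, and it shows that removing this one carbon leaves the two numbers within the usual scatter of each other. For this pair, then, the ethyl and methyl versions cannot be told apart in this measurement, and nothing available here offers any explanation of the size of this step.

What the compounds shown leave open is how far this holds, since the chain appears only as ethyl and methyl and the change itself only alongside the 2-fluorophenyl group. Whether a longer chain such as propyl or butyl, or a chain carrying an amine or a carboxylic acid, would give a step beyond the scatter remains unanswered, as does whether ethyl to methyl would read the same alongside the 4-fluorophenyl group.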